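The source may report more compounds than this note shows. Statements on the series, on what has been measured and on what is new or still open speak of the compounds shown alone.

Compound 2 `O=C(N/N=C/N1CCN(c2cc3c(cc2F)c(=O)c(C(=O)O)cn3C2CC2)CC1)c1ccc(F)cc1` carries a 4-fluorophenyl on its carbonyl carbon. In an ADME assay on HepG2 cells (Homo sapiens) for cytotoxicity, read by MTT assay (a higher number here means a weaker inhibitor, a lower number a stronger inhibitor), compound 2 gives only a limit, > 1280000 nM, and not a number. Compound 1 `O=C(N/N=C/N1CCN(c2cc3c(cc2F)c(=O)c(C(=O)O)cn3C2CC2)CC1)c1cccc(C(F)(F)F)c1` also gives only a limit in this assay, at > 322000 nM. Compound 3 `O=C(N/N=C/N1CCN(c2cc3c(cc2F)c(=O)c(C(=O)O)cn3C2CC2)CC1)c1cccc(F)c1` likewise gives only a limit in this assay, at > 812000 nM. The three steps among them, a step that the two limits leave unreadable from compound 1 to compound 2, a step that the two limits leave unreadable from compound 1 to compound 3 and a step that the two limits leave unreadable from compound 2 to compound 3, rest on the limits (the limit of > 1280000 nM in this assay, at which 1 of the 3 values shown sits), the limit of > 322000 nM in this assay, at which 1 of the 3 values shown sits, and (the limit of > 812000 nM in this assay, at which 1 of the 3 values shown sits), so none of them has a readable size. Compound 4 `CCn1cc(C(=O)O)c(=O)c2cc(F)c(N3CCN(/C=N/NC(=O)c4ccc(F)cc4)CC3)cc21` differs from compound 2 in one place: ethyl in place of cyclopropyl on an aromatic nitrogen, that is, ethyl replaces cyclopropyl on the aromatic nitrogen of the shared core. Within the data shown here, no measured step bears on this particular change. Every measured compound sits at a limit, and the expectation in this assay is a further limit rather than a number. Compound 4 is therefore estimated at 1000000 nM, within a range from 300000 nM to 3000000 nM. The step from compound 2 to compound 4 is expected to be an at least 1.2-fold lower number from compound 2 to compound 4 (0.10 log units; that floor lies within the scatter), nothing readable beyond the scatter.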

Compound 4, half-maximal inhibitory concentration: > 797000 nM
Compound 4: no number, only a limit; the forecaster's own chance of this, stated with the estimate: 85%; the middle value does not contradict the limit.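

Compound 2 and compound 4 both give only a limit in this assay, and the step between them, ethyl in place of cyclopropyl, cannot be read. The compounds shown leave open what actual number any of them would give in this assay, and whether this change on the aromatic nitrogen shifts it.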